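Removing the Acetyl Group from Compound 1

The compounds below may be only part of what the source reports. "The series", "measured", "known", "first", "only" and "open" are said of these compounds alone.

Measured compounds:
compound 1, `CC(=O)c1ccc(N2CCN(C(=O)c3nc4cc(Cl)ccc4s3)CC2)cc1`, 30.8%
compound 2, `CC(=O)c1ccc(N2CCN(C(=O)c3nc4ccccc4s3)CC2)cc1`, 62.3%
compound 3, `O=C(c1nc2ccccc2s1)N1CCN(c2ccncc2)CC1`, 62%

In an ADME assay on RAW264.7 cells (Mus musculus) for cytotoxicity, read by MTT assay, with a stated time of 72 h, tested at 50 ug/mL (on this read-out higher numbers stand for more inhibition at the one concentration tested (going by the name of the read-out) and lower numbers for less inhibition), compound 1 gives the lowest of the three numbers. Compound 3 lies above it, and compound 2 lies further above; both gaps are beyond the scatter. Among the measured compounds shown here, the only single-place step measured, a number 31.5 percentage points higher from compound 1 to compound 2 (beyond the scatter), concerns a chloro group and not the change at hand.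

Compound 4, `O=C(c1nc2cc(Cl)ccc2s1)N1CCN(c2ccccc2)CC1`, differs from compound 1 by hydrogen in place of acetyl on an aromatic carbon. For the measured compounds named here, no measured step follows this change; the chloro group of compound 1 is kept. With nothing to point either way, no step beyond the scatter is expected in this assay, a number 2.2 percentage points higher from compound 1 to compound 4 (within the scatter). Compound 4 is therefore estimated at 33%, within 15% to 55%.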

Compound 4, a percentage reported as inhibition, at one concentration (the size of the read-out at that concentration, not a potency): 41.2%
Estimate against measurement, compound 4: 8.2 percentage points below; low and high end bracket the measured number.
By their numbers in this assay, from the lowest: compound 1; then compound 4; then compounds 3 and 2 (each within the scatter of the next).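

In this assay the change from 4-acetylphenyl to phenyl, with the chloro group kept, gives a number 10.4 percentage points higher from compound 1 to compound 4 (beyond the scatter) and so shows that this position affects the read-out. The acetyl group is not needed for inhibition on this read-out, since the compound without it still registers a modest rise. Nothing measured here explains the step.

Still open, from the compounds shown here alone, is whether the same change gives a similar step on compound 2, which has no chloro group. Also open, going by these compounds, is how an amine or a carboxylic acid at this place would read.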